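The source may report more compounds than this note shows. Statements on the series, on what has been measured and on what is new or still open speak of the compounds shown alone.

Measured so far in a functional assay on CNE-2 cells (Homo sapiens) for cytotoxicity, read by MTT assay, with a stated time of 72 h; a lower number here means a stronger inhibitor, a higher number a weaker inhibitor:
Compound 1 `COc1cc2ncnc(NNC(=S)NC(=O)c3ccc(C(F)(F)F)cc3)c2cc1OC` gives 16500 nM.
Compound 2 `COc1cc2ncnc(NNC(=S)NC(=O)c3ccccc3)c2cc1OC` gives 8180 nM.

Among the measured compounds shown here, compound 2 holds the lower of the two numbers, but the single step joining them, a 2.0-fold lower number from compound 1 to compound 2 (0.30 log units; within the scatter), lies within the scatter, so the two compounds cannot be ranked against each other on these data.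

Compound 3 `COc1cc2ncnc(NNC(=S)NC(=O)c3cccc(Cl)c3)c2cc1OC` has not yet been measured in this assay. It differs from compound 2 by chloro in place of hydrogen on an aromatic carbon. For the measured compounds named here, the only measured step that bears on it is the one on the same aromatic ring, a 2.0-fold lower number from compound 1 to compound 2 (0.30 log units; within the scatter), which stayed within the scatter; that is the whole of the evidence. With nothing beyond the scatter to build on, no step beyond the scatter is expected, and the estimated step from compound 2 to compound 3 is a 1.1-fold higher number from compound 2 to compound 3 (0.04 log units; within the scatter). Compound 3 is therefore expected to give 9000 nM in this assay, estimated to fall between 4000 nM and 20000 nM.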

Compound 3, half-maximal inhibitory concentration: 7460 nM
Compound 3: middle estimate off by 1.2-fold (0.08 log units), on the high side; measured number inside the range.
By their numbers in this assay, from the lowest: compounds 3, 2 and 1 (each within the scatter of the next, the first and the last beyond it).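

Chloro in place of hydrogen on an aromatic carbon, meta to a large group, makes no readable difference in this assay, with a step of a 1.1-fold lower number from compound 2 to compound 3 (0.04 log units; within the scatter). Among the compounds shown here, exchanging 4-(trifluoromethyl)phenyl for 3-chlorophenyl on the carbonyl carbon gives the first step here beyond the scatter, a modest one of a 2.2-fold lower number from compound 1 to compound 3 (0.34 log units; beyond the scatter), but this exchange alters both the group and where it sits, so the data cannot assign the step to either alone. No measured evidence is available to explain either step.

From the compounds shown here alone, it remains open whether an amine or a carboxylic acid on the aromatic carbon that holds chloro in compound 3 would give a step beyond the scatter. Also open, going by these compounds, is whether replacing the carbonyl-bearing benzoyl group with a longer chain would do so.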